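The compounds below may be only part of what the source reports. "The series", "measured", "known", "first", "only" and "open" are said of these compounds alone.

In a functional assay on the whole organism (strain Sprague-Dawley) for inhibition, with Rattus norvegicus as the target, with a stated time of 10 min (a higher number here means that more compound is needed for the effect, a lower number that less compound is needed), compound 1 `O=C(O)c1cnc(-c2ccccc2[N+](=O)[O-])[nH]c1=O` is recorded only as a limit, > 50 mg/kg. Compound 2 `CCOc1ccc(Cl)cc1-c1ncc(C(=O)O)c(=O)[nH]1` carries an ethoxy group but also differs from compound 1 elsewhere. Compound 2 gives 0.5 mg/kg. Compound 3 `CCOC(=O)c1cnc(-c2ccccc2[N+](=O)[O-])[nH]c1=O` offers no number to start from, as its result reads "not determined" (no result reported). The next structure is compound 4 `CCOC(=O)c1cnc(-c2ccccc2OCC)[nH]c1=O`. The change is ethoxy in place of nitro on an aromatic carbon. Among the compounds with values here, no measured step shows what this swap does on its own, so the expectation in this assay is a large move towards a lower dose, resting only on compound 2 at 0.5 mg/kg. For compound 4 the estimated dose is 8 mg/kg, with an expected range of 1 mg/kg to 50 mg/kg.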

Compound 4, dose for 50% inhibition: 2 mg/kg
For compound 4 the middle estimate is 4.0-fold (0.60 log units) above the measured one, within the range that was stated.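

Within the data shown here, compound 3 has no number in this assay, and so no step from it to compound 4 can be read. What ethoxy in place of nitro does on its own stays open among the compounds shown.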